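The source may hold more compounds than are shown below. What is called first, only, known or untested is meant among the compounds shown, and "the series" means these compounds.

Measured in a functional assay on A549 cells (Homo sapiens) for antiproliferative activity, read by MTT assay, with a stated time of 72 h; on this read-out higher numbers stand for weaker inhibition and lower numbers for stronger inhibition:
Compound 1 `CCNC(=O)c1cc(Oc2ccc(NC(=O)c3nn(-c4cccc(F)c4)c(=O)cc3C)cc2)ccn1`: 7410 nM
Compound 2 `CCCNC(=O)c1cc(Oc2ccc(NC(=O)c3nn(-c4ccc(Br)cc4F)c(=O)cc3C)cc2F)ccn1`: 235000 nM

Compound 2, at 235000 nM, has the higher of the two numbers and so the weaker inhibition. Compound 3 `CCCNC(=O)c1cc(Oc2ccc(NC(=O)c3nn(-c4cccc(C(F)(F)F)c4)c(=O)cc3C)cc2F)ccn1` changes one group of compound 2: 3-(trifluoromethyl)phenyl in place of 4-bromo-2-fluorophenyl on an aromatic nitrogen. Within the data shown here, no measured pair differs in just one place, so the guide is loose: compound 1 differs from compound 2 in more than one place, and compound 1 gives 7410 nM. In this assay, a drop beyond the scatter is expected, with an estimated step of a 9.4-fold lower number from compound 2 to compound 3 (0.97 log units; beyond the scatter). The expected value for compound 3 is 25000 nM, with an estimated range of 5000 nM to 120000 nM.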

Compound 3, half-maximal inhibitory concentration: 9240 nM
The estimate for compound 3 lay 2.7-fold (0.43 log units) above the measured number; the range from low to high includes it.
By their numbers in this assay, from the lowest: compounds 1 and 3 (each within the scatter of the next); then compound 2.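

In this assay the group on the aromatic nitrogen matters by itself: with everything else in the molecule unchanged, 3-(trifluoromethyl)phenyl in place of 4-bromo-2-fluorophenyl gives a 25-fold lower number from compound 2 to compound 3 (1.41 log units; beyond the scatter) and this lies beyond the scatter. Among these compounds, this is the first pair that differs in one place only, so the change in number can be tied to this swap. Nothing measured explains the size of the step.

Still open, on these data alone, is whether losing the bromine, losing the fluorine or gaining the trifluoromethyl drives the step. A plain phenyl or a methoxyphenyl group on that nitrogen could help to separate these.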